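A few compounds are considered here, and "the series" means these few. Any claim that something is new, unique, unknown or untested is made for them only; others in the source may bear on it.

Measured compounds:
compound 1, `O=C(Nc1cccc(-n2cc(-c3ccncc3)c(-c3cc(O)cc(Cl)c3)n2)c1)Nc1ccc(Cl)c(Cl)c1`, gives 96% in a functional assay on NCI-H226 cells (Homo sapiens) for inhibition, read by sulforhodamine B assay, with a stated time of 48 h, tested at 1 uM; on this read-out higher numbers stand for a weaker effect at the one concentration tested and lower numbers for a stronger effect
compound 2, `COc1cc(Cl)cc(-c2nn(-c3cccc(NC(=O)Nc4ccc(Cl)c(Cl)c4)c3)cc2-c2ccncc2)c1`, gives 82% in this assay

Compound 2 holds the lower of the two numbers, and on this read-out a lower number means a stronger effect at the single concentration tested. Going by the values given here, the only measured step, a number 14 percentage points lower from compound 1 to compound 2 (beyond the scatter), came with methyl in place of hydrogen on an oxygen on an aromatic ring.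

Compound 3, `COc1cc(Cl)cc(-c2nn(-c3cccc(NC(=O)c4cccc(C(F)(F)F)c4)c3)cc2-c2ccncc2)c1`, has not yet been measured. It differs from compound 2 in this way: 3-(trifluoromethyl)phenyl in place of (3,4-dichlorophenyl)amino on a carbonyl carbon. Among the compounds with values here, the one measured step concerns a different part of the molecule and says nothing directly about what happens at the carbonyl carbon, so there is no measured guide for this change. In the absence of such a guide, the expected outcome is a number close to that of compound 2, with no step beyond the scatter in either direction and a wide range to reflect the uncertainty. Compound 3 is therefore estimated to give 85%, with a range from 65% to 100%. The step this estimate implies, a number 3 percentage points higher from compound 2 to compound 3 (within the scatter), is expected to stay within the usual scatter.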

Compound 3, a percentage reported as activity, at one concentration (the size of the read-out at that concentration, not a potency): 54%
Beside the measured number, compound 3's estimate is 31 percentage points above it; measured number below the stated range.
By their numbers in this assay, from the lowest: compound 3; then compound 2; then compound 1.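

Going by these compounds alone, the carbonyl carbon, which no earlier step touched, turns out to matter for the effect in this assay: putting 3-(trifluoromethyl)phenyl in place of (3,4-dichlorophenyl)amino gave a number 28 percentage points lower from compound 2 to compound 3 (beyond the scatter) at the single concentration tested. Within the data shown here, the only earlier step, a number 14 percentage points lower from compound 1 to compound 2 (beyond the scatter), came from the methyl on oxygen, so this result shows that a second part of the molecule can also shift the read-out. The change is a combined one, however, since it removes the hydrogen-bond donor counted on the leaving group and also replaces the two chlorines with a trifluoromethyl group, and no measurement offered here explains the gain.

These compounds leave open whether the loss of the amino nitrogen or the change of substituents on the ring carries the step, which a 3-(trifluoromethyl)phenylamino group or a 3,4-dichlorophenyl group on the same carbonyl carbon would begin to separate. On these data alone, it is also open how far this position tolerates quite different groups, such as a dimethylamino group or a longer chain like phenethyl.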